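From cyano to acetyl at the assay limit

A few compounds are considered here, and "the series" means these few. Any claim that something is new, unique, unknown or untested is made for them only; others in the source may bear on it.

Values in an ADME assay on HaCaT cells (Homo sapiens) for antiproliferative activity, with a stated time of 48 h; a lower number here means a stronger inhibitor, a higher number a weaker inhibitor:
Compound 1 `CC(=O)c1ccc(-c2ccc(N3CCCC3)nn2)cc1`: > 25000 nM, a limit
Compound 2 `CCN(CC)c1ccc(-c2ccc(C#N)cc2)nn1`: > 25000 nM, a limit

Neither measured compound has yet given a number. All that the measurements show so far is the limit of > 25000 nM in this assay, at which 2 of the 2 values shown sit. Compound 2 stands only at a limit, > 25000 nM.

Compound 3 `CCN(CC)c1ccc(-c2ccc(C(C)=O)cc2)nn1` differs from compound 2 in one place, with acetyl in place of cyano on an aromatic carbon, para to a large group: acetyl in place of cyano on an aromatic carbon. Among the compounds with values here, no step between measured compounds is available to size this change, so no shift beyond the scatter is expected in this assay, in either direction. The estimated step of a number no higher from compound 2 to compound 3 (the limit leaves the size open) reflects that expectation. Another reading reported only as a limit is the likeliest outcome. For compound 3 the estimated value is 25000 nM, with an expected range from 10000 nM to 60000 nM.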

Compound 3, half-maximal inhibitory concentration: 20000 nM
Compound 3: the middle estimate sits 1.3-fold (0.10 log units) above what was measured; low and high end bracket the measured number.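

In this assay, within the data shown here, compound 3 gives 20000 nM, the first reading that is a number and not a limit. Acetyl in place of cyano gives an at least 1.2-fold lower number from compound 2 to compound 3 (0.09 log units; that floor lies within the scatter), and diethylamino in place of pyrrolidin-1-yl gives an at least 1.2-fold lower number from compound 1 to compound 3 (0.09 log units; that floor lies within the scatter). Both steps are only floors set by a limit, so they show that a number can be read on this scaffold but fix the true size of neither change: the limit of > 25000 nM in this assay, at which 2 of the 3 values shown sit.

The compounds shown leave open how far either step really reaches, since the exact values of compound 1 and compound 2 remain unknown. Also open, on these data alone, is whether a carboxylic acid or an amide in the acetyl position, or a morpholine in place of diethylamino, would move the number beyond the scatter.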